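The compounds below may be only part of what the source reports. "The series", "measured", "known", "first", "only" and "open" are said of these compounds alone.

Measured so far in a functional assay on SW480 cells (Homo sapiens) for antiproliferative activity, read by sulforhodamine B assay, with a stated time of 48 h; on this read-out higher numbers stand for weaker inhibition and lower numbers for stronger inhibition:
Compound 1 `COc1ccc(OC)c(/C=C/C(=O)/C=C(O)/C=C/c2cc(OC)ccc2OC)c1` gives 15600 nM
Compound 2 `COc1ccc(C=C(C(=O)/C=C/c2cccc(OC)c2OC)C(=O)/C=C/c2cccc(OC)c2OC)cc1OC` gives 410 nM
Compound 3 `COc1cccc(/C=C/C(=O)C(=Cc2cc(OC)c(OC)c(OC)c2)C(=O)/C=C/c2cccc(OC)c2OC)c1OC` gives 650 nM

On these numbers, compound 3 stands level with compound 2 within the scatter, and the values of both lie far under that of compound 1. The next compound, compound 4 `COc1cc(C=C(C(=O)/C=C/c2cccc(OC)c2OC)C(=O)/C=C/c2cccc(OC)c2OC)cc(Br)c1O`, has not yet been measured. The change leading to it is 3-bromo-4-hydroxy-5-methoxyphenyl in place of 3,4,5-trimethoxyphenyl on a double-bonded chain carbon bound to a double-bonded chain carbon in which 3-bromo-4-hydroxy-5-methoxyphenyl comes in place of 3,4,5-trimethoxyphenyl on a double-bonded chain carbon bound to a double-bonded chain carbon.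

Among the compounds with values here, only one measured step touches this aromatic group: a 1.6-fold higher number from compound 2 to compound 3 (0.20 log units; within the scatter) with methoxy in place of hydrogen on an aromatic carbon. Within the data shown here, no measured compound carries bromine, and that part of the change remains untested. Resting on the small size of a 1.6-fold higher number from compound 2 to compound 3 (0.20 log units; within the scatter) alone, no step beyond the scatter is expected in this assay for the present change, though this expectation is weakly supported. The expected step is a 1.3-fold lower number from compound 3 to compound 4 (0.11 log units; within the scatter) according to this estimate. For compound 4 the estimated value is 500 nM with an expected range from 180 nM to 1400 nM in the same read-out.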

Compound 4, half-maximal inhibitory concentration: 260 nM
For compound 4 the middle estimate is 1.9-fold (0.28 log units) above the measured one; low and high end bracket the measured number.
By their numbers in this assay, from the lowest: compounds 4, 2 and 3 (each within the scatter of the next, the first and the last beyond it); then compound 1.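

In this assay, within the data shown here, the aromatic group on a double-bonded chain carbon bound to a double-bonded chain carbon now produces a step beyond the scatter, a 2.5-fold lower number from compound 3 to compound 4 (0.40 log units; beyond the scatter), whereas the only earlier step touching this group stayed within it, so the position is not indifferent to what the aromatic group carries. Set against 3,4-dimethoxyphenyl, however, 3-bromo-4-hydroxy-5-methoxyphenyl gives a 1.6-fold lower number from compound 2 to compound 4 (0.20 log units; within the scatter), which lies within the scatter, so the change separates compound 4 from the 3,4,5-trimethoxyphenyl compound only and not from the 3,4-dimethoxyphenyl compound. Nothing measured here bears on why this exchange gives a step of this size.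

Because bromine and hydroxy enter together in compound 4, the compounds shown cannot assign the step to either one, and they say nothing about chlorine in place of the bromine or an amine in place of the hydroxy. On these data alone, whether the same aromatic group would have any such effect on the core of compound 1 also remains open.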